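This account rests on a few compounds, and the source may have more. Where it says the series, first, only, none or still open, it means among the compounds named here.

Measured so far in an ADME assay on HepG2 cells (Homo sapiens) for cytotoxicity, read by MTT assay, with a stated time of 7 days; on this read-out higher numbers stand for weaker inhibition and lower numbers for stronger inhibition:

compound 1 `COc1ccc(C2CC(c3ccc(O)cc3)=NN2C(=O)c2cccnc2)cc1C` gives 44800 nM
compound 2 `CCCc1ccc(C2CC(c3ccc(O)cc3)=NN2C(=O)c2cccnc2)cc1` gives 41600 nM
compound 3 `O=C(c1cccnc1)N1N=C(c2ccc(O)cc2)CC1c1ccc([N+](=O)[O-])cc1` gives 18600 nM

Compound 3 has the lowest number of the three, and its gaps to both of the others lie beyond the scatter. Compound 4 `CC(C)c1ccc(C2CC(c3ccc(O)cc3)=NN2C(=O)c2cccnc2)cc1` has not yet been measured. It differs from compound 3 by isopropyl in place of nitro on an aromatic carbon, para to a large group (isopropyl in place of nitro on an aromatic carbon).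

Among the measured compounds shown here, no measured compound carries isopropyl, so the nearest guide is the step of nitro in place of propyl (a 2.2-fold lower number from compound 2 to compound 3 (0.35 log units; beyond the scatter)), which was modest and now runs in reverse. The step to the 4-nitrophenyl compound from the other side (a 2.4-fold lower number from compound 1 to compound 3 (0.38 log units; beyond the scatter)) was of similar size, whereas the step between the two compounds without nitro (a 1.1-fold lower number from compound 1 to compound 2 (0.03 log units; within the scatter)) stayed within the scatter. The size expected in this assay is therefore a modest rise to a higher number (a 2.2-fold higher number from compound 3 to compound 4 (0.33 log units; beyond the scatter)), close to compound 2 (41600 nM). For compound 4 the estimate is 40000 nM (expected range 22000 nM to 70000 nM).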

Compound 4, half-maximal inhibitory concentration: 38700 nM
Beside the measured number, compound 4's estimate is 1.0-fold (0.01 log units) above it; the range from low to high includes it.
By their numbers in this assay, from the lowest: compound 3; then compounds 4, 2 and 1 (each within the scatter of the next).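

In this assay, replacing nitro with isopropyl on an aromatic carbon, para to a large group, gives a modest change (a 2.1-fold higher number from compound 3 to compound 4 (0.32 log units; beyond the scatter)), showing that the gap seen earlier between the nitro and propyl groups also appears with a second alkyl group. The change from propyl to isopropyl stays within the scatter (a 1.1-fold lower number from compound 2 to compound 4 (0.03 log units; within the scatter)), as does the replacement of the whole 4-methoxy-3-methylphenyl group with 4-isopropylphenyl (a 1.2-fold lower number from compound 1 to compound 4 (0.06 log units; within the scatter)), so among these four compounds only compound 3, the nitro compound, stands apart from the others. Nothing available accounts for this separation.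

From the compounds shown here alone, whether the lower number belongs to nitro alone or extends to other groups at this position, such as an amine, a nitrile or a carboxylic acid, remains open. Also open, going by these compounds, is whether a chain longer than propyl would stay level with compound 4.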